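Thiourea replacement on a chromane core: methoxyphenyl to cyanophenyl

The compounds below may be only part of what the source reports. "The series", "measured", "known", "first", "only" and "open" are said of these compounds alone.

Measured compounds:
compound 1 `COc1ccccc1NC(=S)NC1CC(C)(C)Oc2ccc(Br)cc21` — 22000 nM
compound 2 `CC(=O)NC1CC(C)(C)Oc2ccc(Cl)cc21` — > 100000 nM
compound 3 `CC1(C)CC(NC(=S)Nc2cccc([N+](=O)[O-])c2)c2cc(Cl)ccc2O1` — 3000 nM

In a functional assay on U-373MG ATCC cells (Homo sapiens) for inhibition, read by MTT assay, with a stated time of 72 h (on this read-out lower numbers stand for stronger inhibition and higher numbers for weaker inhibition), compound 1 gives 22000 nM, the higher of the two numbers obtained. Compound 3 gives 3000 nM in this assay, a gap from compound 1 that lies beyond the usual scatter. For compound 2, this assay reports only a limit, > 100000 nM, and no number (the limit of > 100000 nM in this assay, at which 1 of the 3 values shown sits).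

Compound 4 `CC1(C)CC(NC(=S)Nc2ccc(C#N)cc2)c2cc(Br)ccc2O1` is not yet measured. It differs from compound 1 in one place: 4-cyanophenyl in place of 2-methoxyphenyl on an amide-type nitrogen. For the measured compounds named here, no measured pair shows this same exchange, so the expected direction rests on the shared core and on compound 3, whose thiourea carries a different aryl group and whose value 3000 nM is the lower of the two numbers. The step from compound 1 to compound 4 is expected to go toward a lower number, of moderate size, a 2.8-fold lower number from compound 1 to compound 4 (0.44 log units; beyond the scatter). Compound 4 is therefore estimated at 8000 nM, in a range from 2000 nM to 30000 nM.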

Compound 4, half-maximal inhibitory concentration: 22000 nM
For compound 4 the middle estimate is 2.8-fold (0.44 log units) below the measured one; low and high end bracket the measured number.
By their numbers in this assay, from the lowest: compound 3; then compounds 1 and 4 (each within the scatter of the next). At a limit, above all of these: compound 2.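

Within this assay the exchange of 2-methoxyphenyl for 4-cyanophenyl on the amide-type nitrogen gives no change at the digits printed from compound 1 to compound 4 (within the scatter) and is the first direct reading of this position, since no earlier pair differed in only one place. It shows that, for these two groups on the bromine-bearing core, this exchange leaves the read-out where it was, so the nitrile-bearing ring offers no gain over the methoxy-bearing one. Nothing measured here accounts for this outcome.

The compounds shown leave open whether an amine or a carboxylic acid on the phenyl ring, or a longer chain in its place, would move the number at this position. For the compounds shown here, they also leave open what the halogen on the core contributes, since no pair isolates that change.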